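The source may hold more compounds than are shown below. What is called first, only, known or untested is meant among the compounds shown, and "the series" means these compounds.

Measured compounds in an assay for inhibition of Tryptophan 2,3-dioxygenase (Homo sapiens), with stated times of 10 min and 60 min; a higher number here means a weaker inhibitor, a lower number a stronger inhibitor:
compound 1, `O=[N+]([O-])c1cccc(CNc2cc(Br)cc3[nH]ncc23)c1`, gives 1600 nM;
compound 2, `O=[N+]([O-])c1cccc(CNc2cc(C(F)(F)F)cc3[nH]ncc23)c1`, gives 5170 nM;
compound 3, `O=[N+]([O-])c1ccc(CNc2cc(Br)cc3[nH]ncc23)cc1`, gives 2230 nM.

Compound 1 and compound 2 differ in one place, (trifluoromethyl in place of bromo on an aromatic carbon), and in this assay the step is a 3.2-fold higher number from compound 1 to compound 2 (0.51 log units; beyond the scatter). Compound 3 has the same atoms as compound 1 joined differently, and the difference between the two cores is not broken down here. Compound 4, `O=[N+]([O-])c1ccc(CNc2cc(C(F)(F)F)cc3[nH]ncc23)cc1`, is not yet measured; it differs from compound 3 by trifluoromethyl in place of bromo on an aromatic carbon, the same kind of change as from compound 1 to compound 2, around the same kind of place. For compound 4 a step of about a 3.1-fold higher number from compound 3 to compound 4 (0.50 log units; beyond the scatter) is expected, resting on the step from compound 1 to compound 2 and on compound 3 giving 2230 nM. Compound 4 is estimated at 7000 nM, likely between 3500 nM and 14000 nM.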

Compound 4, half-maximal inhibitory concentration: > 100000 nM
Compound 4: a limit, no number; the forecaster's own chance of this, stated with the estimate: 5%; middle value at least 14-fold (1.15 log units) away from the limit.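

In this assay compound 4 gives > 100000 nM, which is a limit of the assay and not a number. Trifluoromethyl in place of bromo gives an at least 44-fold higher number from compound 3 to compound 4 (1.65 log units; beyond the scatter), so the direction carries over between the two cores but the size does not: the same change on two cores in this assay, a 3.2-fold higher number (0.51 log units; beyond the scatter) from compound 1 to compound 2 and an at least 44-fold higher number (1.65 log units; beyond the scatter) from compound 3 to compound 4, at least 13-fold (1.14 log units) apart, beyond the scatter of two such steps With only one pair on each core, this does not show why the size differs, nor how large the step from compound 3 really is.

The compounds shown leave open whether other groups at this place, such as chloro, methyl or a nitrile, would behave like bromo or like trifluoromethyl. They also leave open how the step would look if the nitro group gave way to an amine or a carboxylic acid.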